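Swapping a Dimethoxyphenyl for a Bromothiophene

The source may report more compounds than this note shows. Statements on the series, on what has been measured and on what is new or still open speak of the compounds shown alone.

Three measured compounds share one core and differ only in the aryl group attached to the carbonyl carbon. In a functional assay on NCI-H460 cells (Homo sapiens) for antiproliferative activity, read by XTT assay, with a stated time of 72 h (on this read-out lower numbers stand for stronger inhibition and higher numbers for weaker inhibition), compound 1 `COc1ccc(C(=O)/C=C/c2nc3ccccc3cc2-c2ccc(OC)cc2)cc1` gives only a limit, > 10000 nM. Compound 2 `COc1ccc(-c2cc3ccccc3nc2/C=C/C(=O)c2c(OC)cccc2OC)cc1` gives 6630 nM in this assay, and compound 3 `COc1ccc(-c2cc3ccccc3nc2/C=C/C(=O)c2ccc(OC)c(OC)c2)cc1` gives 7540 nM. Compound 2 thus holds the lowest of the two real numbers, but its nearest neighbour is compound 3, with a 1.1-fold higher number from compound 2 to compound 3 (0.06 log units; within the scatter), so the pair cannot be ranked. The step of an at least 1.5-fold lower number from compound 1 to compound 2 (0.17 log units; that floor lies within the scatter) starts from a limit, as the limit of > 10000 nM in this assay, at which 1 of the 3 values shown sits, records, and offers only a floor.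

Compound 4 `COc1ccc(-c2cc3ccccc3nc2/C=C/C(=O)c2ccc(Br)s2)cc1` carries the change (5-bromothiophen-2-yl in place of 2,6-dimethoxyphenyl on a carbonyl carbon). Both measured steps at this position are small or bounded, so no step beyond the scatter is expected for this swap. The estimated step is a 1.1-fold higher number from compound 2 to compound 4 (0.02 log units; within the scatter). Compound 4 is therefore expected to give 7000 nM in this assay, within a range from 2500 nM to 20000 nM.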

Compound 4, half-maximal inhibitory concentration: 5170 nM
Estimate against measurement, compound 4: 1.4-fold (0.13 log units) above; the range from low to high includes it.
By their numbers in this assay, from the lowest: compounds 4, 2 and 3 (each within the scatter of the next). At a limit, above all of these: compound 1.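

Until now this carbonyl carbon had carried only phenyl rings bearing methoxy groups. Compound 4 shows that in this assay a 5-bromothiophen-2-yl group, a five-membered ring with sulfur and bromine and no methoxy at all, can take that place with no step beyond the scatter: the two readable steps are a 1.3-fold lower number from compound 2 to compound 4 (0.11 log units; within the scatter) and a 1.5-fold lower number from compound 3 to compound 4 (0.16 log units; within the scatter). Compound 1 holds only a limit, so an at least 1.9-fold lower number from compound 1 to compound 4 (0.28 log units; that floor lies within the scatter) is no more than a floor: the limit of > 10000 nM in this assay, at which 1 of the 4 values shown sits.

As far as these compounds go, what the bromine adds on its own, apart from the thiophene ring, stays open. So does whether a plain thiophene, or a quite different group on this carbon such as an amine or a carboxylic acid, would give a number beyond the scatter of these.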